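Shifting the amine on a pendant aryl ring

The source may report more compounds than this note shows. Statements on the series, on what has been measured and on what is new or still open speak of the compounds shown alone.

Compound 1 `COc1cc(-c2ncnn2-c2cccc(N)c2)cc(OC)c1OC` gives, in a functional assay on MCF7 cells (Homo sapiens) for antiproliferative activity, read by MTT assay, with a stated time of 72 h (a lower number here means a stronger inhibitor, a higher number a weaker inhibitor), only a limit of > 10000 nM. Compound 2 `COc1cc(-n2ncnc2-c2cccc(Cl)c2)cc(OC)c1OC` likewise shows only a limit, > 10000 nM, in this assay. Compound 1 therefore stands at the limit of > 10000 nM in this assay, at which 2 of the 2 values shown sit, with no measured number to fix its potency. Compound 3 `COc1cc(-c2ncnn2-c2ccc(N)cc2)cc(OC)c1OC` differs from compound 1 in one respect: 4-aminophenyl in place of 3-aminophenyl on an aromatic nitrogen. For the measured compounds named here, no measured step between compounds is available, so the change is judged only from the limits. The step expected here is a number no higher from compound 1 to compound 3 (the limit leaves the size open), a small one. Compound 3 is estimated at 10000 nM, within 2000 nM to 50000 nM, with a fair chance that only a limit is again reported.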

Compound 3, half-maximal inhibitory concentration: > 10000 nM
Compound 3: no number, only a limit; the forecaster's own chance of this, stated with the estimate: 55%; the middle value lies on the limit itself.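

In this assay, for the compounds shown here, compound 3 gives > 10000 nM, again only a limit, so no step from compound 1 to compound 3 can be read. The compounds shown leave open how potent each one actually is, and whether the amine's position matters: the limit of > 10000 nM in this assay, at which 3 of the 3 values shown sit.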